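Working notes: from compound 2 to compound 3

The source may report more compounds than this note shows. Statements on the series, on what has been measured and on what is new or still open speak of the compounds shown alone.

- Compound 1 `Cc1ccc(Nc2ncc(Cl)c(Nc3ccccc3C)n2)cc1`: > 100000 nM
- Compound 2 `Cc1ccccc1Nc1nc(NCc2ccccc2)ncc1Cl`: > 100000 nM

Both entries come from a functional assay on MDA-MB-231 cells (Homo sapiens) for inhibition, read by CCK-8 assay, with a stated time of 48 h; on this read-out higher numbers stand for weaker inhibition of growth and lower numbers for stronger inhibition of growth. The entry for compound 1 is a limit, not a number. Compound 2 likewise stands only at a limit, > 100000 nM. Among the measured compounds shown here, the series so far shows (the limit of > 100000 nM in this assay, at which 2 of the 2 values shown sit).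

Compound 3 `Cc1ccccc1Nc1nc(Nc2ccccn2)ncc1Cl` carries pyridin-2-yl in place of benzyl on a nitrogen on an aromatic ring. For the measured compounds named here, the one measured step at this place is a step that the two limits leave unreadable from compound 1 to compound 2, and its size cannot be read. Going by the values given here, no step of definite size is expected for the new group, since a step that the two limits leave unreadable from compound 1 to compound 2 offers none to carry over. A result near the same limit is the expectation, and a reported limit is quite possible. The estimated step is an at least 1.2-fold lower number from compound 2 to compound 3 (0.09 log units; that floor lies within the scatter). For compound 3 the expected value is 80000 nM, with an estimated range of 20000 nM to 150000 nM.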

Compound 3, concentration for 50% growth inhibition: 11200 nM
Estimate against measurement, compound 3: 7.1-fold (0.85 log units) above, and the stated range ends above it.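

In this assay, among the compounds shown here, pyridin-2-yl on this nitrogen gives the only value that is a number rather than a limit, with an at least 8.9-fold lower number from compound 2 to compound 3 (0.95 log units; beyond the scatter). Set against 4-methylphenyl at the same place, the group gives an at least 8.9-fold lower number from compound 1 to compound 3 (0.95 log units; beyond the scatter), so pyridin-2-yl stands apart from both carbon-only rings shown, beyond the scatter. The step between the two limit compounds cannot be read, and each new step has only a floor, not a full size: the limit compounds are marked by the limit of > 100000 nM in this assay, at which 2 of the 3 values shown sit.

As far as these compounds go, whether the ring nitrogen of pyridin-2-yl carries the step, or the direct link of a smaller ring to the nitrogen, remains open. Plain phenyl and pyridin-3-yl at this place would separate those two readings.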